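A few compounds are considered here, and "the series" means these few. Any claim that something is new, unique, unknown or untested is made for them only; others in the source may bear on it.

Three compounds of the series have numbers in a functional assay on PC-3 cells (Homo sapiens) for antiproliferative activity, read by MTT assay, with a stated time of 72 h; a higher number here means a weaker inhibitor, a lower number a stronger inhibitor. Compound 1 `CCC/C=C/C(=O)Nc1cc2c(N3CCc4ccccc43)ncnc2cc1OC` gives 4240 nM in this assay. Compound 2 `C=C(C)C(=O)Nc1cc2c(N3CCc4ccccc43)ncnc2cc1O[C@@H]1CCOC1` gives 4910 nM in this assay. Compound 3 `COc1cc2ncnc(N3CCCc4ccccc43)c2cc1NC(=O)C=C(C)C` gives 6130 nM in this assay. Compound 3 carries the highest of the three numbers, but its gap to compound 2 and its gap to compound 1 both lie within the scatter of repeated measurements, so no order among the three can be read from these values. Among the measured compounds shown here, no pair of the measured compounds differs in one place only, so no single step has been measured.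

Compound 4 `C/C=C/C(=O)Nc1cc2c(N3CCCc4ccccc43)ncnc2cc1OC` is not yet measured in this assay. It differs from compound 3 by one change: prop-1-en-1-yl in place of 2-methylprop-1-en-1-yl on a carbonyl carbon. The amide carbonyl and its nitrogen stay where they are; only the chain on the carbonyl carbon is exchanged. For the measured compounds named here, compound 1 and compound 2 differ from compound 3 at other places as well, so no measured pair isolates this chain. Going by the values given here, with no step of this kind on record, the expectation is that the change from compound 3 to compound 4 brings no shift beyond the scatter, a 1.2-fold lower number from compound 3 to compound 4 (0.09 log units; within the scatter). Compound 4 is expected to give 5000 nM in this assay, within a range of 2000 nM to 12000 nM.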

Compound 4, half-maximal inhibitory concentration: 7520 nM
Estimate against measurement, compound 4: 1.5-fold (0.18 log units) below; the range from low to high includes it.
By their numbers in this assay, from the lowest: compounds 1, 2, 3 and 4 (each within the scatter of the next).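

In this assay, among the compounds shown here, the exchange of 2-methylprop-1-en-1-yl for prop-1-en-1-yl on a carbonyl carbon gives a 1.2-fold higher number from compound 3 to compound 4 (0.09 log units; within the scatter) and is the first step that isolates a single place. Going from 4 carbon atoms to 3 in this chain, with the double bond kept and the amide carbonyl and its nitrogen unchanged, therefore produces no shift that can be told apart from repeat-measurement noise, so this pair does not separate the two chains. No supporting measurement on either group bears on this result, and the step offers no explanation beyond its size.

One step with two closely related chains says little about how far this place can be varied, and a chain ending in a dimethylamine, a carboxylic acid or a longer saturated alkyl chain on the same carbonyl carbon could still behave differently. For the compounds shown here, it also remains open whether the same exchange would give a similar step on the core of compound 1, since no pair on that core isolates this chain.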